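Benzyloxy in place of nitro on a carboxylic acid

A few compounds are considered here, and "the series" means these few. Any claim that something is new, unique, unknown or untested is made for them only; others in the source may bear on it.

In a functional assay on KB cells (Homo sapiens) for antiproliferative activity, read by MTT assay, with a stated time of 72 h (on this read-out lower numbers stand for stronger inhibition and higher numbers for weaker inhibition), three compounds have been measured. Compound 1 (`CCOC(=O)c1cc(-c2ccc(OC)c(OCc3ccccc3)c2)c(-c2cc(OC)c(OC)c(OC)c2)s1`), an ethyl ester carrying benzyloxy, gives > 100000 nM as a limit of the assay and not a number. The carboxylic acid compound 2 (`COc1ccc(-c2cc(C(=O)O)sc2-c2cc(OC)c(OC)c(OC)c2)cc1`) gives 8650 nM in this assay and the nitro-bearing acid compound 3 (`COc1ccc(-c2cc(C(=O)O)sc2-c2cc(OC)c(OC)c(OC)c2)cc1[N+](=O)[O-]`) gives 43700 nM there, the higher of the two true numbers. Within the data shown here, the step between these two acids is a 5.1-fold higher number from compound 2 to compound 3 (0.70 log units; beyond the scatter) and it is the only measured step of a single change, modest in size but beyond the scatter.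

Compound 4 (`COc1ccc(-c2cc(C(=O)O)sc2-c2cc(OC)c(OC)c(OC)c2)cc1OCc1ccccc1`) is the acid still to be measured. It carries benzyloxy in place of nitro on an aromatic carbon, ortho to a methoxy group and meta to a large group (benzyloxy in place of nitro on an aromatic carbon). Among the measured compounds shown here, no measured step covers this exchange directly. The nearest guide is a 5.1-fold higher number from compound 2 to compound 3 (0.70 log units; beyond the scatter) as a modest change on that same carbon. Compound 1 also carries benzyloxy but stands at > 100000 nM as a limit and offers no number to build on. No step beyond the scatter is therefore expected in this assay. The estimated 1.7-fold lower number from compound 3 to compound 4 (0.24 log units; within the scatter) stays inside that scatter. Compound 4 is expected at 25000 nM with an estimated range of 6000 nM to 90000 nM in this measurement.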

Compound 4, half-maximal inhibitory concentration: > 100000 nM
Compound 4: a limit, no number; the forecaster's own chance of this, stated with the estimate: 20%; middle value at least 4.0-fold (0.60 log units) away from the limit.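

On the aromatic carbon ortho to a methoxy group, a second group has now been read against nitro, and benzyloxy gives the weaker result in this assay, with an at least 2.2-fold higher number from compound 3 to compound 4 (0.35 log units; beyond the scatter). Against the acid that carries hydrogen on this carbon, the change is an at least 11-fold higher number from compound 2 to compound 4 (1.06 log units; beyond the scatter), so both groups shown here give higher numbers than hydrogen, and benzyloxy, with more heavy atoms than nitro, gives the larger step of the two. Compound 4 now stands at a limit of the assay and not a number, as does the ester compound 1, so the step between these two cannot be read, and the effect of the ethyl ester on the benzyloxy compounds stays unknown: the limit of > 100000 nM in this assay, at which 2 of the 4 values shown sit.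

The compounds shown leave open how an amine, a hydroxyl group or a chlorine atom on this same carbon would read, and with only hydrogen, nitro and benzyloxy in hand, no trend across groups can be settled. They also leave open how the ethyl ester would read on the core of compound 2, which carries hydrogen at this place.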